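This account rests on a few compounds, and the source may have more. Where it says the series, first, only, none or still open, it means among the compounds named here.

Three compounds share one core. Compound 1 `O=C1C(c2ccccc2)CC(c2ccccc2)C(=O)N1c1ccccc1` gives 38.3% in a functional assay on the whole organism (strain Swiss albino) for inhibition, with Mus musculus as the target, in the maximal electroshock model, with a stated time of 2 h, at a dose of 25 mg/kg by the intraperitoneal route; a higher number here means more inhibition at the dose given (going by the name of the read-out), a lower number less inhibition. Compound 2 `O=C1C(c2ccccc2)CC(c2ccccc2)C(=O)N1c1cccc(Cl)c1` gives 32.2% in this assay. Compound 3 `Cc1ccccc1N1C(=O)C(c2ccccc2)CC(c2ccccc2)C1=O` gives 66.1% in this assay, the highest of the three; its nearest neighbour is compound 1, with a number 27.8 percentage points higher from compound 1 to compound 3 (beyond the scatter). Compound 4 `Cc1ccc(N2C(=O)C(c3ccccc3)CC(c3ccccc3)C2=O)cc1` has not been measured; it differs from compound 3 in one place: 4-methylphenyl in place of 2-methylphenyl on an amide-type nitrogen in a ring. Three measured steps change the ring on the amide-type nitrogen: a methyl in place of hydrogen gave a number 27.8 percentage points higher from compound 1 to compound 3 (beyond the scatter), a chloro gave a number 6.1 percentage points lower from compound 1 to compound 2 (within the scatter), and a full ring exchange gave a number 33.9 percentage points higher from compound 2 to compound 3 (beyond the scatter). None moves a methyl within that ring, so the outcome is uncertain. For compound 4 a downward step of a number 18.1 percentage points lower from compound 3 to compound 4 (beyond the scatter) in this assay is expected. Compound 4 is estimated at 48%, between 28% and 70%.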

Compound 4, a percentage reported as inhibition, in the whole organism at one dose (the size of the read-out at that dose, not a potency): 43.3%
Compound 4: the middle estimate sits 4.7 percentage points above what was measured; measured number inside the range.
By their numbers in this assay, from the lowest: compounds 2, 1 and 4 (each within the scatter of the next, the first and the last beyond it); then compound 3.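

The two compounds have the same atoms, yet moving the methyl from 2-methylphenyl to 4-methylphenyl in this assay gives a number 22.8 percentage points lower from compound 3 to compound 4 (beyond the scatter), so where the methyl sits on this ring matters. As 4-methylphenyl, adding the methyl gives only a number 5 percentage points higher from compound 1 to compound 4 (within the scatter), a change within the scatter, unlike the 2-methylphenyl case. Exchanging 3-chlorophenyl for 4-methylphenyl gives a number 11.1 percentage points higher from compound 2 to compound 4 (beyond the scatter). Nothing available explains why the position matters. As far as these compounds go, whether an ethyl group or an amine in place of the methyl of 2-methylphenyl would keep the higher number remains open.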